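The source may hold more compounds than are shown below. What is called first, only, known or untested is meant among the compounds shown, and "the series" means these compounds.

Working notes on the series. Compound 1, `COC(=O)N1CCCc2cc(S(=O)(=O)N3CC(c4ccccc4)NC3=O)ccc21`, gives 1150 nM in a functional assay on A549 cells (Homo sapiens) for antiproliferative activity, read by MTT assay; on this read-out higher numbers stand for weaker inhibition and lower numbers for stronger inhibition. Within the data shown here, compound 2, `CCCOC(=O)N1CCCc2cc(S(=O)(=O)N3CC(c4ccccc4)NC3=O)ccc21`, gives 1030 nM in the same assay; the only step on record, a 1.1-fold lower number from compound 1 to compound 2 (0.05 log units; within the scatter), leaves the two within the scatter of each other, so no order between compound 1 and compound 2 can be read from these numbers.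

Compound 3, `O=C(CCl)NC(=O)N1CCCc2cc(S(=O)(=O)N3CC(c4ccccc4)NC3=O)ccc21`, has not yet been measured. The change from compound 2 to compound 3 is ((chloromethyl)carbonyl)amino in place of propoxy on a carbonyl carbon. Among the measured compounds shown here, the one measured step concerns only lengthening of the chain on the oxygen side of the carbonyl and says nothing about replacing that oxygen by a ((chloromethyl)carbonyl)amino group, so there is no direct precedent for the step to compound 3.

With no step beyond the scatter anywhere in the series, compound 3 is expected to give a number near that of compound 2, with a step of a 1.0-fold lower number from compound 2 to compound 3 (0.01 log units; within the scatter) and a wide range to allow for the untested change. The estimate for compound 3 is 1000 nM, between 300 nM and 3500 nM.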

Compound 3, half-maximal inhibitory concentration: 449 nM
Beside the measured number, compound 3's estimate is 2.2-fold (0.35 log units) above it, within the range that was stated.
By their numbers in this assay, from the lowest: compound 3; then compounds 2 and 1 (each within the scatter of the next).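

In this assay, the group on the carbonyl carbon, whose other neighbour is the amide-type nitrogen in a ring, can shift the read-out: ((chloromethyl)carbonyl)amino in place of propoxy gives a 2.3-fold lower number from compound 2 to compound 3 (0.36 log units; beyond the scatter), and in place of methoxy it gives a 2.6-fold lower number from compound 1 to compound 3 (0.41 log units; beyond the scatter). Among these compounds, the earlier change on the oxygen side, a 1.1-fold lower number from compound 1 to compound 2 (0.05 log units; within the scatter), did not separate its two compounds, so this is the first modest difference. The entering group carries a chlorine and a hydrogen-bond donor that the leaving groups lack, but nothing available bears on the origin of the step.

On these data alone, it remains open whether the chlorine matters. The compounds shown do not tell how an acetylamino group, with hydrogen in place of the chlorine, or a plain amine on the same carbonyl carbon would compare.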